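Replacing a difluorobenzyl with an acetonyl group on the piperazine

A few compounds are considered here, and "the series" means these few. Any claim that something is new, unique, unknown or untested is made for them only; others in the source may bear on it.

Compound 1 `CCN(CC)c1ccc2cc(C(=O)c3ccc(N4CCN(C(=O)CN5CCN(C(=O)CCl)CC5)CC4)cc3)oc2c1`: 5520 nM
Compound 2 `CCN(CC)c1ccc2cc(C(=O)c3ccc(N4CCN(C(=O)CN5CCN(S(=O)(=O)C6CC6)CC5)CC4)cc3)oc2c1`: 28100 nM
Compound 3 `CCN(CC)c1ccc2cc(C(=O)c3ccc(N4CCN(C(=O)CN5CCN(Cc6ccc(F)c(F)c6)CC5)CC4)cc3)oc2c1`: 6400 nM

Of the compounds shown here, three sharing one core have been tested in a functional assay on HeLa cells (Homo sapiens) for cytotoxicity, read by MTT assay, with a stated time of 48 h; a higher number here means a weaker inhibitor, a lower number a stronger inhibitor. Compound 3 stands second highest of the three; its nearest neighbour is compound 1, at a step of a 1.2-fold higher number from compound 1 to compound 3 (0.06 log units; within the scatter), while the step of a 4.4-fold lower number from compound 2 to compound 3 (0.64 log units; beyond the scatter) is the only one that clearly separates it from another compound. Compound 4 `CCN(CC)c1ccc2cc(C(=O)c3ccc(N4CCN(C(=O)CN5CCN(CC(C)=O)CC5)CC4)cc3)oc2c1` differs from compound 3 by acetyl in place of 3,4-difluorophenyl on a saturated chain carbon bound to an amine nitrogen in a ring. Within the data shown here, no measured step matches this change: the steps of a 5.1-fold higher number from compound 1 to compound 2 (0.71 log units; beyond the scatter) and a 4.4-fold lower number from compound 2 to compound 3 (0.64 log units; beyond the scatter) show that swapping the group on that ring nitrogen can move this assay modestly, whereas a 1.2-fold higher number from compound 1 to compound 3 (0.06 log units; within the scatter) shows it need not. On this basis, compound 4 is expected to show a 1.4-fold higher number from compound 3 to compound 4 (0.15 log units; within the scatter), a modest change at most, with the direction uncertain. The estimate for compound 4 is therefore 9000 nM, within a range of 3000 nM to 30000 nM.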

Compound 4, half-maximal inhibitory concentration: 2760 nM
For compound 4 the middle estimate is 3.3-fold (0.51 log units) above the measured one, outside the stated range (below it).
By their numbers in this assay, from the lowest: compounds 4, 1 and 3 (each within the scatter of the next, the first and the last beyond it); then compound 2.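

In this assay the acetyl of compound 4 replaces 3,4-difluorophenyl with a 2.3-fold lower number from compound 3 to compound 4 (0.37 log units; beyond the scatter), so this place tolerates losing that aromatic ring without any loss in this read-out. The 2-oxopropyl group also gives a 10-fold lower number from compound 2 to compound 4 (1.01 log units; beyond the scatter), the largest step in the set, which widens the range seen on this ring nitrogen. Against (chloromethyl)carbonyl it gives a 2.0-fold lower number from compound 1 to compound 4 (0.30 log units; within the scatter), so these two groups cannot be told apart here. On these data alone, whether an amine or a carboxylic acid on that chain carbon would keep this level remains open, as does whether a longer ketone chain would. Nothing at hand explains these steps.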